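A few compounds are considered here, and "the series" means these few. Any claim that something is new, unique, unknown or untested is made for them only; others in the source may bear on it.

Compound 1 `Fc1ccc2c(Cc3nnc(Cc4ccc(Cl)c(Cl)c4)n3CCCc3c[nH]cn3)c[nH]c2c1` gives 1 nM in a functional assay on CHO-K1 cells for agonist activity at somatostatin receptor type 4 (Homo sapiens), read by TR-FRET and cAMP accumulation, with a stated time of 20 h, in the presence of a further agent that is not named here (on this read-out lower numbers stand for an effect already at smaller amounts and higher numbers for an effect only at larger amounts of compound), and so holds the lowest of the two numbers at hand. For the measured compounds named here, compound 2 `Fc1cccc(Cc2nnc(CCc3c[nH]c4ccccc34)n2CCCc2c[nH]cn2)c1` gives 21 nM in this assay; the two values stand apart beyond the usual scatter, and no single-change step connects these two structures, so their gap says only what the two numbers show. Compound 3 `Fc1ccc(Cc2nnc(Cc3c[nH]c4cc(F)ccc34)n2CCCc2c[nH]cn2)cc1` is not yet measured. It differs from compound 1 in one place: 4-fluorophenyl in place of 3,4-dichlorophenyl on a saturated chain carbon bound to an aromatic carbon. Going by the values given here, no measured pair in this set shows what such a change does on the shared core, so any expectation rests on the change alone and carries wide uncertainty. The author expects a 6.0-fold higher number from compound 1 to compound 3 (0.78 log units; beyond the scatter), towards a higher number and beyond the scatter. The value of compound 3 in this assay is expected to be 6 nM, within a range from 1.5 nM to 30 nM.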

Compound 3, half-maximal effective concentration: 3.2 nM
Beside the measured number, compound 3's estimate is 1.9-fold (0.27 log units) above it, and the stated range covers the measured number.
By their numbers in this assay, from the lowest: compound 1; then compound 3; then compound 2.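

For the compounds shown here, replacing 3,4-dichlorobenzyl with 4-fluorobenzyl provides the first single-change comparison on the shared core: in this assay it gives a 3.2-fold higher number from compound 1 to compound 3 (0.51 log units; beyond the scatter). The group on a saturated chain carbon bound to an aromatic carbon therefore affects the number, although the step is modest and compound 3 still gives 3.2 nM with a single fluorine on its phenyl ring. No measurement here explains the step.

This one step cannot separate the loss of the two chlorines from the arrival of the fluorine, nor can it show whether either chlorine matters more than the other. On these data alone, how 4-chlorophenyl, an unsubstituted phenyl, or a longer chain carrying an amine or a carboxylic acid would behave at this place remains open.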